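Moving a Hydroxyl Group within a Series at the Limit

The compounds below may be only part of what the source reports. "The series", "measured", "known", "first", "only" and "open" are said of these compounds alone.

Compound 1, `Oc1ccccc1-c1cc(-c2cccc(F)c2)cc(-c2ccccc2O)n1`, in a functional assay on T47D cells (Homo sapiens) for inhibition (a lower number here means a stronger inhibitor, a higher number a weaker inhibitor), reaches only the limit > 50000 nM.
Compound 2, `Oc1ccc(-c2cc(-c3cccc(F)c3)cc(-c3ccccc3O)n2)cc1`, in this assay reaches only the limit > 50000 nM.
Compound 3, `Oc1ccccc1-c1cc(-c2cccc(C(F)(F)F)c2)cc(-c2ccccc2O)n1`, in this assay reaches only the limit > 50000 nM.

Compound 3 stands where its two companions stand: at a limit of this assay rather than at a number, and the limit line the limit of > 50000 nM in this assay, at which 3 of the 3 values shown sit, shows that all three values sit there. The step that the two limits leave unreadable from compound 1 to compound 3 cannot be read from two limits, and neither can a step that the two limits leave unreadable from compound 1 to compound 2.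

Compound 4, `Oc1ccc(-c2cc(-c3cccc(C(F)(F)F)c3)cc(-c3ccccc3O)n2)cc1`, has not yet been measured. It differs from compound 3 by 4-hydroxyphenyl in place of 2-hydroxyphenyl on an aromatic carbon. The measured step that bears most directly on this change is a step that the two limits leave unreadable from compound 1 to compound 2, the same exchange of hydroxyphenyl groups on the shared core carrying fluoro rather than trifluoromethyl; its size stays unreadable. Among the measured compounds shown here, no measured step gives a direction, and nothing in the data points away from the limit. Compound 4 is therefore expected to remain at the limit as well, with a step that the limit leaves unreadable from compound 3 to compound 4 that carries no real information. The estimate for compound 4 in this assay is 70000 nM, from 25000 nM to 200000 nM, most probably reported again only as a limit.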

Compound 4, half-maximal inhibitory concentration: > 50000 nM
Compound 4: a limit, no number (the forecaster's own chance of this, stated with the estimate: 85%); the middle value does not contradict the limit.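

In this assay compound 4 reaches only a limit, > 50000 nM. Among the compounds shown here, no new step can therefore be read, neither between compound 3 and compound 4 nor between compound 2 and compound 4. The compounds shown leave open how strongly any of them inhibits and whether either exchange changes that, with every value at one limit: the limit of > 50000 nM in this assay, at which 4 of the 4 values shown sit.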